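Notes on the sulfur-linked chain in the chalcone series

The source may hold more compounds than are shown below. What is called first, only, known or untested is meant among the compounds shown, and "the series" means these compounds.

Measured so far in a functional assay on MGC-803 cells (Homo sapiens) for inhibition, read by sulforhodamine B assay, with a stated time of 72 h, tested at 10 uM; on this read-out lower numbers stand for less inhibition and higher numbers for more inhibition at the one concentration tested (going by the name of the read-out):
Compound 1, `CCc1cc(Nc2ccc(C(=O)/C=C/c3cccc(Br)n3)cc2)n2nc(SCc3ccccc3)nc2n1`: compound 1 gives 63%
Compound 2, `Cc1cc(Nc2ccc(C(=O)/C=C/c3cccc(Br)n3)cc2)n2nc(SCc3ccc(Cl)cc3)nc2n1`: compound 2 gives 90.2%
Compound 3, `Cc1nc2nc(SCc3ccc(Cl)cc3)nn2c(Nc2ccc(C(=O)/C=C/c3cccc(Br)n3)cc2)c1C`: compound 3 gives 72.5%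

Compound 2 stands highest of the three numbers in this assay; compound 3 is nearest to it and compound 1 furthest, both beyond the scatter. Going by the values given here, the one single-change step recorded runs from compound 2 to compound 3, a number 17.7 percentage points lower from compound 2 to compound 3 (beyond the scatter), a modest fall.

Compound 4, `Cc1cc(Nc2ccc(C(=O)/C=C/c3cccc(Br)n3)cc2)n2nc(SCCCc3ccccc3)nc2n1`, differs from compound 2 in one place: phenethyl in place of 4-chlorophenyl on a saturated chain carbon bound to a sulfur. Among the compounds with values here, no measured step touches this position, so the change from compound 2 to compound 3, which concerns an aromatic carbon of the core, gives no direct guide. What the numbers show is that compound 2 sits high and that the single recorded alteration lowered it. Within the data shown here, with no step on the sulfur-bound chain to lean on, the estimate for compound 4 is held close to compound 2 with a wide range.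

Compound 4 is expected to give 80% in this assay, between 60% and 95%. The expected step is a number 10.2 percentage points lower from compound 2 to compound 4 (beyond the scatter).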

Compound 4, a percentage reported as inhibition, at one concentration (the size of the read-out at that concentration, not a potency): 76.7%
Estimate against measurement, compound 4: 3.3 percentage points above; the range from low to high includes it.
By their numbers in this assay, from the lowest: compounds 1, 3 and 4 (each within the scatter of the next, the first and the last beyond it); then compound 2.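

In this assay the sulfur-bound chain gives its first reading, a number 13.5 percentage points lower from compound 2 to compound 4 (beyond the scatter), so this position does respond to substitution. Compound 4 still gives 76.7%, which shows that replacing 4-chlorobenzyl with 3-phenylpropyl lowers the number without abolishing inhibition at the one concentration tested. The step changes two things at once, removing the chlorine and lengthening the chain, and it cannot assign the fall to either one. No measured evidence bears on why the number changes at this position.

Plain benzyl and a chlorine-bearing 3-phenylpropyl, each on the core of compound 2, would separate the two changes. Going by these compounds, how an amine or a carboxylic acid on this chain would read also remains open.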